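Trading a Lactam Arm for a Dimethylcarbamoyl Proline

The source may hold more compounds than are shown below. What is called first, only, known or untested is meant among the compounds shown, and "the series" means these compounds.

Of the compounds shown here, three sharing one core have been measured in a physicochemical assay for solubility; on this read-out higher numbers stand for higher solubility and lower numbers for lower solubility. Compound 1 `O=C(CN1CCCC1)N1CCC(NS(=O)(=O)c2cc(S(=O)(=O)c3ccccc3)ccc2C(F)(F)F)CC1` gives 25000 nM, compound 2 `CC(C)(C)OC(=O)N1CCC[C@@H]1C(=O)N1CCC(NS(=O)(=O)c2cc(S(=O)(=O)c3ccccc3)ccc2C(F)(F)F)CC1` gives 25000 nM, and compound 3 `O=C1CC[C@@H](C(=O)N2CCC(NS(=O)(=O)c3cc(S(=O)(=O)c4ccccc4)ccc3C(F)(F)F)CC2)N1` gives 100000 nM, the highest of the three, with a 4.0-fold higher number from compound 1 to compound 3 (0.60 log units; beyond the scatter) and a 4.0-fold higher number from compound 2 to compound 3 (0.60 log units; beyond the scatter). Compound 4 `CN(C)C(=O)N1CCC[C@H]1C(=O)N1CCC(NS(=O)(=O)c2cc(S(=O)(=O)c3ccccc3)ccc2C(F)(F)F)CC1` is the next variation: 1-(dimethylcarbamoyl)pyrrolidin-2-yl in place of 5-oxopyrrolidin-2-yl on a carbonyl carbon. The entering group, like that of compound 2, carries no hydrogen-bond donor, so the step of a 4.0-fold higher number from compound 2 to compound 3 (0.60 log units; beyond the scatter) is the closest guide, pointing to a return toward the level of compound 2. A modest decrease is therefore expected, a 3.3-fold lower number from compound 3 to compound 4 (0.52 log units; beyond the scatter). Compound 4 is estimated at 30000 nM, with a likely range from 12000 nM to 80000 nM.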

Compound 4, solubility: 100000 nM
The estimate for compound 4 lay 3.3-fold (0.52 log units) below the measured number, and the stated range ends below it.
By their numbers in this assay, from the lowest: compounds 1 and 2 (each within the scatter of the next); then compounds 3 and 4 (each within the scatter of the next).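

In this assay there is no change at the digits printed from compound 3 to compound 4 (within the scatter) when 1-(dimethylcarbamoyl)pyrrolidin-2-yl replaces 5-oxopyrrolidin-2-yl on this carbonyl carbon, so the level of compound 3 is held with 0 hydrogen-bond donors in this group. Donor count alone does not sort these compounds: neither group carries a donor, yet there is a 4.0-fold higher number from compound 2 to compound 4 (0.60 log units; beyond the scatter) when 1-(dimethylcarbamoyl)pyrrolidin-2-yl replaces 1-(tert-butoxycarbonyl)pyrrolidin-2-yl, and there is also a 4.0-fold higher number from compound 1 to compound 4 (0.60 log units; beyond the scatter) in this set. No available measurement explains these steps. As far as these compounds go, whether an amine or a carboxylic acid in this group would keep that level remains open.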